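Ester variation on the macrocyclic lactam scaffold

The compounds below may be only part of what the source reports. "The series", "measured", "known", "first", "only" and "open" are said of these compounds alone.

Measured compounds:
compound 1 `CO[C@@H](C(=O)NC1CC[C@@H](OC(=O)CCc2cccnc2)CNC1=O)[C@H](O)[C@@H](O)[C@H](O)/C=C/C(C)(C)C` — 460 nM
compound 2 `CCCCCCCCCCCCCC(=O)O[C@@H]1CCC(NC(=O)[C@H](OC)[C@H](O)[C@@H](O)[C@H](O)/C=C/C(C)(C)C)C(=O)NC1` — a limit, < 10 nM
compound 3 `CCCCCCCCCCCCCC(=O)O[C@H]1CCC(NC(=O)[C@H](OC)[C@H](O)[C@@H](O)[C@H](O)/C=C/C(C)(C)C)C(=O)N(C)C1` — 10 nM

In an in vivo functional assay on the whole organism (MDA-MB-435 cells, Homo sapiens) for antiproliferative activity (a higher number here means a weaker inhibitor, a lower number a stronger inhibitor), compound 1 gives the highest of the two numbers; compound 3 sits well below it. Compound 2 reaches only a limit in this assay, a limit at which one value sits (the limit of < 10 nM in this assay, at which 1 of the 3 values shown sits). Within the data shown here, the one measured step, an at least 46-fold lower number from compound 1 to compound 2 (1.66 log units; beyond the scatter), is large but concerns a different exchange. Compound 4 `CO[C@@H](C(=O)NC1CC[C@@H](OC(=O)/C=C/c2ccccc2)CNC1=O)[C@H](O)[C@@H](O)[C@H](O)/C=C/C(C)(C)C` differs from compound 1 by 2-phenylethenyl in place of 2-(pyridin-3-yl)ethyl on a carbonyl carbon. The step into this assay is expected to be modest, a 2.3-fold lower number from compound 1 to compound 4 (0.36 log units; beyond the scatter), towards a lower number. Compound 4 is estimated at 200 nM, within 60 nM to 700 nM.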

Compound 4, half-maximal inhibitory concentration: 20 nM
For compound 4 the middle estimate is 10-fold (1.00 log units) above the measured one; the whole stated range lies above it.
By their numbers in this assay, from the lowest: compounds 3 and 4 (each within the scatter of the next); then compound 1.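

In this assay, an aromatic ester on the core of compound 1 can also give a large step, not only the long undecyl chain: a 23-fold lower number from compound 1 to compound 4 (1.36 log units; beyond the scatter). The exchange keeps the count of 8 heavy atoms and an aromatic ring, yet it changes both the ring, from pyridin-3-yl to phenyl, and the link, from ethyl to ethenyl. No measured property at hand bears on the cause of this step.

Which of the two changes carries the step remains open. A 2-phenylethyl or a 2-(pyridin-3-yl)ethenyl group on the same carbonyl carbon would separate them.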